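Acetyl gives way to cyano: an expected step

The source may report more compounds than this note shows. Statements on the series, on what has been measured and on what is new or still open speak of the compounds shown alone.

Measured so far:
- compound 2, `CC(=O)/C(=C\c1c(-c2ccccc2)[nH]c2ccccc12)S(=O)(=O)c1ccccc1`, 1600 nM
- compound 1, `COc1ccc(-c2[nH]c3ccccc3c2/C=C(\C#N)S(=O)(=O)c2ccccc2)cc1`, 4700 nM

Of the compounds shown here, two have been measured in a functional assay on UO-31 cells (Homo sapiens) for inhibition, read by sulforhodamine B assay, with a stated time of 48 h; a lower number here means a stronger inhibitor of growth, a higher number a weaker inhibitor of growth. Compound 2 gives the lower of the two numbers, 1600 nM. Going by the values given here, compound 1 gives 4700 nM, a step beyond the usual scatter, though the two structures differ in more than one place and no single step is drawn between them.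

Compound 3, `N#C/C(=C\c1c(-c2ccccc2)[nH]c2ccccc12)S(=O)(=O)c1ccccc1`, has not yet been measured. It differs from compound 2 in one place: cyano in place of acetyl on a double-bonded chain carbon bound to a double-bonded chain carbon and a sulfonyl sulfur. Among the compounds with values here, no pair of measured compounds shows this exact change, so the direction rests on the two numbers alone. Compound 1, which also carries a cyano group at this position, gave the higher number, so a modestly weaker inhibitor is expected. The expected step of a 1.9-fold higher number from compound 2 to compound 3 (0.27 log units; within the scatter) is a small loss, near the edge of the scatter. Compound 3 is estimated at 3000 nM, within a range from 1000 nM to 9000 nM.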

Compound 3, concentration for 50% growth inhibition: 6700 nM
Compound 3: middle estimate off by 2.2-fold (0.35 log units), on the low side; the range from low to high includes it.
By their numbers in this assay, from the lowest: compound 2; then compounds 1 and 3 (each within the scatter of the next).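

Going by these compounds alone, compound 3 gives the first direct reading of this change: in this assay, cyano in place of acetyl on a double-bonded chain carbon bound to a double-bonded chain carbon and a sulfonyl sulfur gives a 4.2-fold higher number from compound 2 to compound 3 (0.62 log units; beyond the scatter). This single change therefore costs growth inhibition beyond the scatter, whereas hydrogen in place of methoxy on an aromatic carbon gives a 1.4-fold higher number from compound 1 to compound 3 (0.15 log units; within the scatter) and does not separate those two compounds. No measurement shown here explains why acetyl gives the lower number at this position.

The compounds shown leave open how a carboxylic acid, an amide or a longer chain ketone would read at this carbon. They also leave open whether a methoxy group on the aromatic ring would read the same alongside acetyl as it does alongside cyano.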